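Azidomethyl to diisopropylcarbamoyl on the shared core

The source may hold more compounds than are shown below. What is called first, only, known or untested is meant among the compounds shown, and "the series" means these compounds.

Values in a functional assay on MCF7 cells (Homo sapiens) for antiproliferative activity, read by MTT assay, with a stated time of 48 h; on this read-out higher numbers stand for weaker inhibition and lower numbers for stronger inhibition:
- Compound 1 `CC(C)=CCC[C@]1(C)/C=C/[C@@H](OC(=O)C=C(C)C)[C@](C)(O)/C=C/C(=O)/C(CF)=C\C1` gives 240 nM
- Compound 2 `CC(C)=CCC[C@]1(C)/C=C/[C@@H](OC(=O)C=C(C)C)[C@](C)(O)/C=C/C(=O)/C(CN=[N+]=[N-])=C\C1` gives 4890 nM

Going by the values given here, compound 2 stands at the higher of the two numbers, and compound 1 is its only neighbour. Compound 3 `CC(C)=CCC[C@]1(C)/C=C/[C@@H](OC(=O)C=C(C)C)[C@](C)(O)/C=C/C(=O)/C(C(=O)N(C(C)C)C(C)C)=C\C1` has diisopropylcarbamoyl in place of azidomethyl on a double-bonded ring carbon. Among the compounds with values here, the only measured step, a 20-fold higher number from compound 1 to compound 2 (1.31 log units; beyond the scatter), is large. It swaps azido for fluoro on the saturated chain carbon bound to that same double-bonded ring carbon, so it shows that the number can move far with a change at this place. Within the data shown here, no measured compound carries a carbamoyl group, so that step gives no direction for this change. In this assay, no step beyond the scatter is expected, though with wide uncertainty. The expected step is a 1.2-fold higher number from compound 2 to compound 3 (0.09 log units; within the scatter). The estimate for compound 3 is 6000 nM, with an expected range of 1500 nM to 24000 nM.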

Compound 3, half-maximal inhibitory concentration: 17200 nM
For compound 3 the middle estimate is 2.9-fold (0.46 log units) below the measured one; the measured number falls inside the stated range.
By their numbers in this assay, from the lowest: compound 1; then compound 2; then compound 3.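

In this assay, diisopropylcarbamoyl in place of azidomethyl gives a 3.5-fold higher number from compound 2 to compound 3 (0.55 log units; beyond the scatter), a modest step, while the same group in place of fluoromethyl gives a 72-fold higher number from compound 1 to compound 3 (1.86 log units; beyond the scatter), the largest step among the three compounds. A carbamoyl group on this double-bonded ring carbon therefore does not bring the number back towards that of compound 1, and compound 3 now sits at the high end of the series, with compound 1 at the low end. No measurement on hand bears on what lies behind this order.

Left open is whether a hydroxymethyl group, a carboxylic acid or an unsubstituted amide at this place would give a number nearer to compound 1 or to compound 3. Also open, going by these compounds, is whether the same order holds with another ester in place of the ((2-methylprop-1-en-1-yl)carbonyl)oxy group.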